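Methyl Ester of a Nitronyl Nitroxide Amino Acid Conjugate

A few compounds are considered here, and "the series" means these few. Any claim that something is new, unique, unknown or untested is made for them only; others in the source may bear on it.

Compound 1: `COC(=O)[C@@H](N)CCCNC(=N)NC(=O)COc1ccc(C2=NC(C)(C)C(C)(C)N2O)cc1` gives 93600 nM
Compound 2: `CC1(C)N(O)C(c2ccc(OCCNC(=O)C[C@H](N)C(=O)O)cc2)=[N+]([O-])C1(C)C` gives 42300 nM

Of the compounds shown here, two have been measured in a functional assay on PC-12 cells (Rattus norvegicus) for inhibition, read by MTT assay; a higher number here means that more compound is needed for the effect, a lower number that less compound is needed. Compound 2 has the lower of the two numbers, so less of it is needed for the effect in this assay. Compound 1 needs more, and the gap between the two values is wider than the usual scatter of such measurements; since the two structures differ in several places at once, the values alone are all that can be said of this pair.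

Compound 3 is `COC(=O)[C@@H](N)CC(=O)NCCOc1ccc(C2=[N+]([O-])C(C)(C)C(C)(C)N2O)cc1` and is the next candidate for this assay. It differs from compound 2 in a single spot: methyl in place of hydrogen on an oxygen next to a carbonyl group. The free acid becomes its methyl ester; everything else in the molecule stays as it is.

For the measured compounds named here, no single-point step of this kind has been measured here, so the expectation rests on the closeness of the two structures. The step from compound 2 to compound 3 is expected to stay within the scatter, a 1.2-fold higher number from compound 2 to compound 3 (0.07 log units; within the scatter). Compound 3 is therefore estimated at 50000 nM, with a range from 20000 nM to 125000 nM.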

Compound 3, half-maximal effective concentration: 39000 nM
For compound 3 the middle estimate is 1.3-fold (0.11 log units) above the measured one; the range from low to high includes it.
By their numbers in this assay, from the lowest: compounds 3 and 2 (each within the scatter of the next); then compound 1.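

For the compounds shown here, this pair gives the first comparison in which only one place changes. In this assay, placing methyl on an oxygen next to a carbonyl group, which turns the carboxy group into methoxycarbonyl, gives a 1.1-fold lower number from compound 2 to compound 3 (0.04 log units; within the scatter) and so stays within the usual scatter of repeated measurements. At this position, the free acid and its methyl ester therefore cannot be told apart by this read-out, so in this pair the hydrogen on that oxygen makes no measurable difference to the amount of compound needed. Nothing available here offers an explanation for this result.

As far as these compounds go, one ester pair says little about the position as a whole, so it remains open whether a longer chain on the same oxygen, such as an ethyl or benzyl ester, or an amide in place of the ester, would also read like compound 2 and compound 3. From the compounds shown here alone, it also remains open whether the same change would read alike on a different side chain, as would be seen by comparing compound 1, itself a methyl ester, with its free carboxylic acid.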